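Bromo to Methylsulfanyl: Expectation for Compound 4

The compounds below may be only part of what the source reports. "The series", "measured", "known", "first", "only" and "open" are said of these compounds alone.

Compound 1 `Cc1ccc(S/C(=C/c2ccc(Br)cc2)C(=O)c2ccc(Cl)cc2)cc1` gives 25000 nM in a functional assay on DU-145 cells (Homo sapiens) for inhibition, read by trypan blue exclusion, with a stated time of 96 h; on this read-out higher numbers stand for weaker inhibition of growth and lower numbers for stronger inhibition of growth.
Compound 2 `O=C(/C(=C\c1ccc(Br)cc1)SCc1ccc(Cl)cc1)c1ccc(Cl)cc1` gives 1000 nM in this assay.
Compound 3 `O=C(/C(=C\c1ccc(Br)cc1)Sc1ccc(Br)cc1)c1ccc(Cl)cc1` gives 1000 nM in this assay.

Compound 2 stands level with compound 3 at the digits given, and together they have the lowest numbers of the three. Compound 1 is the furthest away: a 25-fold lower number from compound 1 to compound 2 (1.40 log units; beyond the scatter), and likewise a 25-fold lower number from compound 1 to compound 3 (1.40 log units; beyond the scatter). Between the two lower compounds there is no change at the digits printed from compound 2 to compound 3 (within the scatter).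

Compound 4 `CSc1ccc(/C=C(/SCc2ccc(Cl)cc2)C(=O)c2ccc(Cl)cc2)cc1` is not yet measured. It differs from compound 2 in one place: methylsulfanyl in place of bromo on an aromatic carbon.

Going by the values given here, no measured step touches this group. The two large steps, from compound 1, change what sits on the sulfur, and the step between compound 2 and compound 3 changes the same part and gives no change. A halogen in place of a small carbon group on an aromatic carbon gave a large step in a 25-fold lower number from compound 1 to compound 3 (1.40 log units; beyond the scatter), but at a different place, so it does not carry over directly. With nothing measured at the place changed here, the expectation is a step of no more than the usual scatter, in no firm direction: a 1.5-fold higher number from compound 2 to compound 4 (0.18 log units; within the scatter) is expected. Compound 4 is therefore estimated at 1500 nM, within a range from 500 nM to 5000 nM.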

Compound 4, concentration for 50% growth inhibition: 25000 nM
The estimate for compound 4 lay 17-fold (1.22 log units) below the measured number, outside the stated range (above it).
By their numbers in this assay, from the lowest: compounds 2 and 3 (each within the scatter of the next); then compounds 1 and 4 (each within the scatter of the next).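

In this assay, the position carrying the bromo group turns out to be far from silent: methylsulfanyl in its place gives a 25-fold higher number from compound 2 to compound 4 (1.40 log units; beyond the scatter), which on this read-out means much weaker inhibition of growth. Going by these compounds alone, the earlier steps changed only the group on the sulfur, and that part of compound 2 could go from 4-chlorobenzyl to 4-bromophenyl with no change beyond the scatter, so this is the first sign that the other end of the molecule matters as well. The swap is small by simple counts, with one bromine leaving and one carbon plus one sulfur entering, yet nothing shown here says what about this change produces so large a step.

On these data alone, with only bromo and methylsulfanyl seen at this position, it remains open whether bromo is specifically favoured or methylsulfanyl specifically disfavoured, a question that other groups there, such as methoxy, fluoro or an amine, could help to settle. As far as these compounds go, it is also open whether the same swap would give a step of similar size with 4-bromophenyl rather than 4-chlorobenzyl on the sulfur.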